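Working notes: from compound 3 to compound 4

The source may hold more compounds than are shown below. What is called first, only, known or untested is meant among the compounds shown, and "the series" means these compounds.

Measured in a functional assay on HCT-116 cells (Homo sapiens) for inhibition, read by fluorescence, with a stated time of 48 h (on this read-out higher numbers stand for weaker inhibition of growth and lower numbers for stronger inhibition of growth), so far
- compound 1 `CC(C)[C@H](N)C(=O)OCCCOC1(c2ccc(Cl)cc2)c2ccccc2C(=O)N1Cc1ccc(Cl)cc1` gives 16000 nM
- compound 2 `N[C@H](C(=O)OCCCOC1(c2ccc(Cl)cc2)c2ccccc2C(=O)N1Cc1ccccc1)c1ccccc1` gives 14000 nM
- compound 3 `O=C1c2ccccc2C(OCCCO)(c2ccc(Cl)cc2)N1Cc1ccccc1` gives 79000 nM

Compound 3 stands highest of the three on this assay and so shows the weakest inhibition of growth, with compound 1 and compound 2 both well below it. Compound 4 `CC(C)[C@H](N)C(=O)OCC(C)(C)COC1(c2ccc(Cl)cc2)c2ccccc2C(=O)N1Cc1ccccc1` is still unmeasured. The change leading to it is 1-((((1-amino-2-methylpropyl)carbonyl)oxy)methyl)-1-methylethyl in place of 2-hydroxyethyl on a saturated chain carbon bound to an oxygen on a saturated carbon and lies on a saturated chain carbon bound to an oxygen on a saturated carbon.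

Going by the values given here, one measured step bears on this directly: a 5.6-fold higher number from compound 2 to compound 3 (0.75 log units; beyond the scatter) where hydrogen takes the place of (amino(phenyl)methyl)carbonyl on an oxygen on a saturated carbon. Read in reverse, that step links a carbonyl group bearing an amino function at this end of the chain to a lower number. Compound 1 (16000 nM) carries the 1-amino-2-methylpropyl carbonyl unit and also sits low, though it differs elsewhere as well. Among the compounds with values here, no measured compound has the branched chain of compound 4, so that part of the change remains untested.

A modest drop beyond the scatter is therefore expected in this assay rather than no change. The expected step is a 4.9-fold lower number from compound 3 to compound 4 (0.69 log units; beyond the scatter) and points to stronger inhibition of growth. For compound 4 the estimated value is 16000 nM (6000 nM to 45000 nM).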

Compound 4, concentration for 50% growth inhibition: 20000 nM
Compound 4: the middle estimate sits 1.3-fold (0.10 log units) below what was measured; low and high end bracket the measured number.
By their numbers in this assay, from the lowest: compounds 2, 1 and 4 (each within the scatter of the next); then compound 3.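

In this assay, 1-((((1-amino-2-methylpropyl)carbonyl)oxy)methyl)-1-methylethyl in place of 2-hydroxyethyl on a saturated chain carbon bound to an oxygen on a saturated carbon gives a 4.0-fold lower number from compound 3 to compound 4 (0.60 log units; beyond the scatter), so this change brings stronger inhibition of growth. The earlier compounds shown here offered only a 5.6-fold higher number from compound 2 to compound 3 (0.75 log units; beyond the scatter), a step at the ester oxygen with the chain left as it was, whereas the new step shows that a lower number than that of compound 3 can also be reached with a branched chain at this position. Nothing at hand accounts for the size or direction of the step.

The new step combines the branching of the chain with the addition of the amino ester, so the compounds shown leave open how much of the step belongs to each part. The same branched chain ending in a free hydroxyl would address that question, while an amide in place of the ester or a longer chain would show how far this position accepts further change.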